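Cyclopentenone series: cytotoxicity on ECV-304 cells, working notes

The source may hold more compounds than are shown below. What is called first, only, known or untested is meant among the compounds shown, and "the series" means these compounds.

Measured compounds and their values:
- compound 1 `COc1ccc(C2=C(c3cc(OC)c(OC)c(OC)c3)C(=O)C(O[SiH2]C(C)(C)C)C2)cc1OC(C)C`: > 100 ug/mL
- compound 2 `COC(=O)c1cc(C2=C(c3cc(OC)c(OC)c(OC)c3)C(=O)CC2O[SiH2]C(C)(C)C)ccc1OC`: > 100 ug/mL
- compound 3 `COc1cc(C2=C(c3cc(C)c(OC)c(C)c3)C(O)CC2=O)cc(OC)c1OC`: > 100 ug/mL

All three values come from an ADME assay on ECV-304 cells (Homo sapiens) for cytotoxicity, read by MTT assay, with a stated time of 72 h; a lower number here means a stronger inhibitor, a higher number a weaker inhibitor. Each of them is a limit of the assay, not a number. Compound 2 stands at > 100 ug/mL, and this is only a limit. The same holds for the other two compounds: the limit of > 100 ug/mL in this assay, at which 3 of the 3 values shown sit. Since no compound gives a number, no step between measured compounds can be stated, and nothing separates compound 2 from compound 1 or compound 3 on what is shown.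

The unmeasured compound 4 `COc1ccc(OC)c(C2=C(c3cc(OC)c(OC)c(OC)c3)C(=O)CC2O[SiH2]C(C)(C)C)c1` differs from compound 2 in one place: 2,5-dimethoxyphenyl in place of 4-methoxy-3-(methoxycarbonyl)phenyl on a double-bonded ring carbon.

For the measured compounds named here, with no measured step in hand, the expectation rests on the three limits alone. Every compound shown sits at the limit, so for compound 4 the expected step that the limit leaves unreadable from compound 2 to compound 4 in this assay is none beyond the scatter, and the most probable outcome is that compound 4 again reports only a limit. The estimate for compound 4 in this assay is 150 ug/mL, with a range from 60 ug/mL to 400 ug/mL.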

Compound 4, half-maximal inhibitory concentration: 6.5 ug/mL
The estimate for compound 4 lay 23-fold (1.36 log units) above the measured number, and the stated range ends above it.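

In this assay, 2,5-dimethoxyphenyl in place of 4-methoxy-3-(methoxycarbonyl)phenyl on a double-bonded ring carbon gives an at least 15-fold lower number from compound 2 to compound 4 (1.18 log units; beyond the scatter). Compound 2 gives > 100 ug/mL, which is a limit and not a number, so this step fixes only a minimum size and not an exact one. For the compounds shown here, the earlier compounds showed no separation at all, whereas this pair shows that the group on this ring carbon, with the rest of compound 2 unchanged, can carry the read-out from the limit to a measurable number, and compound 4 is so far the only compound in the set to give one: the limit of > 100 ug/mL in this assay, at which 3 of the 4 values shown sit.

The change replaces the whole aromatic group, so the compounds shown cannot separate the loss of the methoxycarbonyl group from the arrival of the second methoxy group or from the new arrangement of methoxy groups on that ring. From the compounds shown here alone, it also remains open how a phenyl group bearing a carboxylic acid, an amine or a longer alkoxy chain on this ring carbon would read in this assay.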